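Cyclohexylmethyl in place of tert-butyl on the ring amine

The source may report more compounds than this note shows. Statements on the series, on what has been measured and on what is new or still open speak of the compounds shown alone.

Compound 1 `Cc1cccc2sc(NC(=O)CCN3CCN(C(C)(C)C)CC3)nc12` gives 200 nM in an assay on membranes from liver for displacement of a labelled ligand from Sigma intracellular receptor 2 (Rattus norvegicus), read by scintillation counting, with a stated time of 120 min; on this read-out higher numbers stand for weaker inhibition and lower numbers for stronger inhibition.
Compound 3 `CCCCCCN1CCN(CCC(=O)Nc2nc3c(C)cccc3s2)CC1` gives 158 nM.
Compound 2 `Cc1cccc2sc(NC(=O)CCN3CCN(CCCN(C)C)CC3)nc12` reaches only > 1000 nM, a limit of the assay.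

Of the two numbers shown, compound 1 has the higher, with compound 3 nearest at a 1.3-fold lower number from compound 1 to compound 3 (0.10 log units; within the scatter). Compound 2 sits at the limit of > 1000 nM in this assay, at which 1 of the 3 values shown sits. Compound 4 `Cc1cccc2sc(NC(=O)CCN3CCN(CC4CCCCC4)CC3)nc12` differs from compound 1 by cyclohexylmethyl in place of tert-butyl on an amine nitrogen in a ring. Going by the values given here, two measured steps bear on this change: a 1.3-fold lower number from compound 1 to compound 3 (0.10 log units; within the scatter), where a hexyl chain of carbon only left the result within the scatter, and an at least 5.0-fold higher number from compound 1 to compound 2 (0.69 log units; beyond the scatter), where a chain carrying dimethylamino weakened it. Cyclohexylmethyl, with no hydrogen-bond acceptors, resembles hexyl more than the dimethylamino chain, so no step beyond the scatter is expected. Compound 4 is estimated at 160 nM, between 60 nM and 420 nM, an expected step of a 1.3-fold lower number from compound 1 to compound 4 (0.10 log units; within the scatter).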

Compound 4, inhibition constant: 519 nM
Beside the measured number, compound 4's estimate is 3.2-fold (0.51 log units) below it, outside the stated range (above it).
By their numbers in this assay, from the lowest: compounds 3 and 1 (each within the scatter of the next); then compound 4. At a limit, above all of these: compound 2.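

In this assay, carbon-only groups on this ring amine nitrogen prove not to be interchangeable: cyclohexylmethyl gives a 2.6-fold higher number from compound 1 to compound 4 (0.41 log units; beyond the scatter), and the ring also separates it from the open hexyl chain, with a 3.3-fold higher number from compound 3 to compound 4 (0.52 log units; beyond the scatter), whereas hexyl had given a 1.3-fold lower number from compound 1 to compound 3 (0.10 log units; within the scatter). Only a floor can be read for the remaining step: an at least 1.9-fold lower number from compound 2 to compound 4 (0.28 log units; that floor lies within the scatter). Compound 2 stands at a limit: the limit of > 1000 nM in this assay, at which 1 of the 4 values shown sits.

From the compounds shown here alone, what remains open is whether the ring itself or the size of the group accounts for this step. A benzyl or cyclopropylmethyl group on this nitrogen could help to separate the two.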